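The source may report more compounds than this note shows. Statements on the series, on what has been measured and on what is new or still open speak of the compounds shown alone.

compound 1 `CCc1ccc(SCc2ccc(C(=O)Nc3ccccc3N)cc2)cc1` gives 91.4%
compound 2 `Nc1ccccc1NC(=O)c1ccc(CSc2cccc(F)c2)cc1` gives 72.7%

In a functional assay on A549 cells (Homo sapiens) for inhibition, read by CCK-8 assay, with a stated time of 72 h, tested at 8 uM (a higher number here means more inhibition of growth at the concentration tested, a lower number less inhibition of growth), compound 2 gives 72.7% and is the lower of the two measured compounds. Compound 3 `Nc1ccccc1NC(=O)c1ccc(CSc2ccc(Br)cc2)cc1` keeps the core of compound 2 and differs from it by 4-bromophenyl in place of 3-fluorophenyl on a sulfur. Within the data shown here, one measured step bears on this change, at the same sulfur: a number 18.7 percentage points lower from compound 1 to compound 2 (beyond the scatter) is modest in size and replaces a 4-ethylphenyl group with the 3-fluorophenyl group that now leaves. The entering 4-bromophenyl group shares its numbering with the 4-ethylphenyl group of compound 1, which gives 91.4% in this assay. Among the measured compounds shown here, no measured compound carries bromine, so this comparison is only a weak guide. For the measured compounds named here, a rise is therefore expected, of modest size and somewhat smaller than the one measured step. The expected change is a number 11.3 percentage points higher from compound 2 to compound 3 (beyond the scatter) in this assay. For compound 3 the estimated value is 84% (expected range 68% to 96%) in this assay when it is measured.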

Compound 3, percent growth inhibition at one concentration: 45.7%
For compound 3 the middle estimate is 38.3 percentage points above the measured one, and the stated range ends above it.
By their numbers in this assay, from the lowest: compound 3; then compound 2; then compound 1.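

In this assay the 4-bromophenyl group on the sulfur does not follow the 4-ethylphenyl group of compound 1, though the two share their numbering: the result is a number 27 percentage points lower from compound 2 to compound 3 (beyond the scatter) and, against the better compound, a number 45.7 percentage points lower from compound 1 to compound 3 (beyond the scatter) in a step that is large. The exchange of ethyl for bromo on an aromatic carbon is therefore enough on its own to separate these two compounds widely, so the numbering of the group gives no reliable guide here, and the three compounds now show that this aryl group on the sulfur strongly shapes growth inhibition at the concentration tested. Nothing measured here accounts for the fall with bromine.

The step from the 3-fluorophenyl to the 4-bromophenyl group changes both the halogen and its numbering at once, so the compounds shown do not separate these two changes, and a 4-fluorophenyl or a 3-bromophenyl group would bear directly on that. On these data alone, whether the loss is particular to bromine, or would also appear with a 4-chlorophenyl, a 4-methoxyphenyl or a longer chain such as 4-propylphenyl, remains open.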